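The compounds below may be only part of what the source reports. "The series", "measured", "known", "first", "only" and "open" are said of these compounds alone.

Within the data shown here, compound 3, whose structure is `O=c1c(CSC(=S)N2CCOCC2)coc2ccccc12`, is one of three compounds measured in a functional assay on MDA-MB-435S cells (Homo sapiens) for antiproliferative activity, read by MTT assay, with a stated time of 72 h; a higher number here means a weaker inhibitor, a lower number a stronger inhibitor. In this assay compound 3 gives 3900 nM, which puts it second highest of the three numbers. Among the measured compounds shown here, its nearest neighbour is compound 2, with the structure `Cc1ccc2c(=O)c(CSC(=S)N3CCOCC3)coc2c1`, which in this assay gives 5500 nM; the only single-point step among the measured compounds, a 1.4-fold lower number from compound 2 to compound 3 (0.15 log units; within the scatter), is the loss of a methyl group from an aromatic carbon, and it stays within the scatter. The compound furthest from compound 3 is compound 1, with the structure `COc1ccc2occ(CSC(=S)N3CCCCC3)c(=O)c2c1`, which in this assay gives 930 nM.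

The next compound, compound 4, has the structure `O=c1c(CSC(=S)N2CCCCC2)coc2ccccc12`. It differs from compound 3 in one place: piperidin-1-yl in place of morpholin-4-yl on a thiocarbonyl carbon. For the measured compounds named here, no measured step isolates this exact change. Compound 1 carries the same piperidin-1-yl group but also differs from compound 3 at a second position, so its lower number can only hint at the direction, not fix the size. On that basis, a lower number for compound 4 is expected, and the step of a 2.6-fold lower number from compound 3 to compound 4 (0.41 log units; beyond the scatter) is the estimate of its size. Compound 4 is therefore expected to give about 1500 nM, with a plausible range from 600 nM to 4000 nM.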

Compound 4, half-maximal inhibitory concentration: 470 nM
The estimate for compound 4 lay 3.2-fold (0.50 log units) above the measured number, outside the stated range (below it).
By their numbers in this assay, from the lowest: compounds 4 and 1 (each within the scatter of the next); then compounds 3 and 2 (each within the scatter of the next).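

Among these compounds, on the shared core, the step of an 8.3-fold lower number from compound 3 to compound 4 (0.92 log units; beyond the scatter) in this assay gives the first direct reading of this change on the thiocarbonyl carbon. The two rings have the same count of heavy atoms, and the swap of morpholin-4-yl for piperidin-1-yl exchanges the ring oxygen for a carbon and removes a hydrogen-bond acceptor, so this single exchange accompanies the whole step. The step of a 2.0-fold lower number from compound 1 to compound 4 (0.30 log units; within the scatter) adds that, with piperidin-1-yl in place, hydrogen and methoxy on the aromatic carbon cannot be told apart, so among these compounds only the change on the thiocarbonyl carbon moves the number beyond the scatter, while the methoxy change and the methyl change between compound 2 and compound 3 do not.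

As far as these compounds go, it remains open whether other amines on the thiocarbonyl carbon, such as pyrrolidin-1-yl, piperazin-1-yl or an open-chain diethylamino group, would match the number of the piperidin-1-yl ring or move away from it. No measurement shown here explains the size of this step.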